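A few compounds are considered here, and "the series" means these few. Any claim that something is new, unique, unknown or untested is made for them only; others in the source may bear on it.

The study brings together two measured compounds and one that still awaits a number. Compound 1, `CSc1[nH]ccc2ncnc1-2`, is the smaller of the pair; in a functional assay (Homo sapiens) for inhibition of Nucleic Acid, tested at 100 uM (a higher number here means more inhibition at the concentration tested (going by the name of the read-out), a lower number less inhibition), compound 1 gives 4%. Compound 2, `OC[C@H]1O[C@@H](n2cnc3c(NCc4ccccc4)nccc32)C[C@@H]1O`, carries a sugar and a benzylamino group on a related core, and in this assay compound 2 gives 15%. Among the two values, compound 2 stands highest, and its nearest neighbour, compound 1, sits below it by a margin beyond the usual scatter.

Compound 3, `Nc1nccc2c1ncn2[C@H]1C[C@H](O)[C@@H](CO)O1`, keeps the sugar of compound 2 but differs in one place: hydrogen in place of benzyl on a nitrogen on an aromatic ring. Within the data shown here, no measured pair in this set shows a step of exactly this kind, so the expectation rests on the two values alone. Since the lower value belongs to the compound lacking the benzyl group, compound 3 is expected to move downward from compound 2, and the step of a number 9 percentage points lower from compound 2 to compound 3 (within the scatter) is estimated to be modest, near the edge of the scatter. For compound 3 in this assay the estimate is 6%, expected to fall between -5% and 20%.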

Compound 3, a percentage reported as inhibition, at one concentration (the size of the read-out at that concentration, not a potency): 18%
Compound 3: the middle estimate sits 12 percentage points below what was measured; the measured number falls inside the stated range.
By their numbers in this assay, from the lowest: compound 1; then compounds 2 and 3 (each within the scatter of the next).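

In this assay, cutting benzylamino back to amino, with hydrogen in place of benzyl on a nitrogen on an aromatic ring, gives a step of a number 3 percentage points higher from compound 2 to compound 3 (within the scatter). Among these compounds, this is the first comparison in the set between compounds that differ in one place, and it shows that at this position the benzyl group, with its six-membered aromatic ring of carbon only, can be lost without the read-out moving beyond the scatter, so the two compounds cannot be told apart in this read-out. No measurement at hand offers an explanation for this result.

With only hydrogen and benzyl seen on this nitrogen, the compounds shown leave open whether a methyl group, a longer alkyl chain such as phenethyl, or an acetyl group there would give a number that stands clear of the scatter. They also leave open what a carboxylic acid or an amine in place of the hydroxymethyl group on the sugar would do, and, since each number comes from a single concentration, they say nothing about potency.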